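Solubility notes: replacing cyclopropyl on the ring nitrogen

The compounds below may be only part of what the source reports. "The series", "measured", "known", "first", "only" and "open" are said of these compounds alone.

Measured in a physicochemical assay for solubility, measured as kinetic solubility; a lower number here means a less soluble compound, a higher number a more soluble compound:
- Compound 1 `CCC/N=C1\S/C(=C\c2ccc(O)c(Cl)c2)C(=O)N1C1CCOCC1`: 70000 nM
- Compound 2 `CCC/N=C1\S/C(=C\c2ccc(O)c(Cl)c2)C(=O)N1C1CC1`: 79000 nM

Compound 2 gives 79000 nM and lies within the scatter of compound 1, so the two numbers cannot be told apart.

Next in line is compound 3 `CCC/N=C1\S/C(=C\c2ccc(O)c(Cl)c2)C(=O)N1c1ccccc1C`, not yet measured in this assay. The change is 2-methylphenyl in place of cyclopropyl on an amide-type nitrogen in a ring.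

Within the data shown here, only one measured step bears on this, the exchange of oxan-4-yl for cyclopropyl at the same place: a 1.1-fold higher number from compound 1 to compound 2 (0.05 log units; within the scatter). That step is a weak guide, since the data hold no aromatic group at this place. The entering group is the larger one by the count given, and the expectation of a lower number rests on that alone. A step within the scatter cannot be excluded.

The expected step is a 2.3-fold lower number from compound 2 to compound 3 (0.35 log units; beyond the scatter).

For compound 3 the estimate is 35000 nM, with an expected range of 10000 nM to 80000 nM.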

Compound 3, solubility: 79000 nM
The estimate for compound 3 lay 2.3-fold (0.35 log units) below the measured number, within the range that was stated.
By their numbers in this assay, from the lowest: compounds 1, 2 and 3 (each within the scatter of the next).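

Exchange of cyclopropyl for 2-methylphenyl on the amide-type nitrogen in a ring gives no change at the digits printed from compound 2 to compound 3 (within the scatter) in this assay, and exchange of oxan-4-yl for the same group gives a 1.1-fold higher number from compound 1 to compound 3 (0.05 log units; within the scatter). This place now carries its first six-membered aromatic ring of carbon only, and with 7 heavy atoms entering where cyclopropyl has 3, the heavy-atom count gives no separation among compounds 1, 2 and 3, whose values cannot be told apart. No supporting measurement bears on the reason for this result.

The compounds shown leave open whether a charged group at this place, such as an amine or a carboxylic acid, would stay within the scatter of these three compounds. Also open, going by these compounds, is how a plain phenyl or a longer chain such as n-butyl would compare with 2-methylphenyl here, so the flat readout covers only the three groups in hand and cannot yet be stated as a rule for this position.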